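Replacing the group on the amide nitrogen of compound 2

The compounds below may be only part of what the source reports. "The series", "measured", "known", "first", "only" and "open" are said of these compounds alone.

Compound 1 `CC(=O)NCc1csc(NC(=O)c2cc(C(C)(C)C)nn2Cc2ccccc2)n1` in a physicochemical assay for solubility, read by nephelometry, measured as kinetic solubility, at pH 2.0; a lower number here means a less soluble compound, a higher number a more soluble compound: 12.5 ug/mL
Compound 2 `CN(C)Cc1csc(NC(=O)c2cc(C(C)(C)C)nn2Cc2ccccc2)n1` in this assay: > 100 ug/mL (a limit)

Compound 2 stands at > 100 ug/mL in this assay, which is a limit of the assay and not a number. Going by the values given here, only one measured step bears on what follows. As far as these compounds go, this step, an at least 8.0-fold higher number from compound 1 to compound 2 (0.90 log units; beyond the scatter), lies beyond the scatter and rests on (the limit of > 100 ug/mL in this assay, at which 1 of the 2 values shown sits), so its full size stays open. Compound 3 `CC(C)(C)c1cc(C(=O)Nc2ccncc2)n(Cc2ccccc2)n1` differs from compound 2 by pyridin-4-yl in place of 4-((dimethylamino)methyl)-1,3-thiazol-2-yl on an amide-type nitrogen, and the dimethylamino group gained in the measured step leaves with that change. Among the compounds with values here, a step of similar or smaller size towards a lower number is therefore expected in this assay, with an at least 8.0-fold higher number from compound 1 to compound 2 (0.90 log units; beyond the scatter) as the only guide. The estimated change is an at least 2.2-fold lower number from compound 2 to compound 3 (0.34 log units; beyond the scatter), though it could prove smaller. For compound 3 the expected value is 45 ug/mL, with an estimated range from 12 ug/mL to 100 ug/mL.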

Compound 3, solubility: > 100 ug/mL
Compound 3: a limit, no number (the forecaster's own chance of this, stated with the estimate: 25%); middle value at least 2.2-fold (0.34 log units) away from the limit.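

In this assay compound 3 gives > 100 ug/mL as a limit of the assay and not a number. Going by these compounds alone, no step from compound 2 to compound 3 can be read: the limit of > 100 ug/mL in this assay, at which 2 of the 3 values shown sit.

The compounds shown leave open how far apart compound 2 and compound 3 truly lie in this assay and which of them reads higher.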